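Piperazin-1-yl to 6-fluoropyridin-3-yl on the shared core

The source may hold more compounds than are shown below. What is called first, only, known or untested is meant among the compounds shown, and "the series" means these compounds.

Among the compounds with values here, in a physicochemical assay for solubility (on this read-out higher numbers stand for higher solubility and lower numbers for lower solubility), compound 2 `O=S(=O)(Nc1nccs1)c1ccc2c(c1)OCC[C@@H]2c1ccc(C(F)(F)F)cc1N1CCNCC1` stands highest of the two numbers so far at 288000 nM and compound 1 `Cc1nc(-c2cc(C(F)(F)F)ccc2[C@H]2CCOc3cc(S(=O)(=O)Nc4nccs4)ccc32)co1` lies lower at 61000 nM on the same read-out. Compound 3 `O=S(=O)(Nc1nccs1)c1ccc2c(c1)OCC[C@@H]2c1ccc(C(F)(F)F)cc1-c1ccc(F)nc1` is still unmeasured. The change is 6-fluoropyridin-3-yl in place of piperazin-1-yl on an aromatic carbon and it sits on an aromatic carbon, ortho to a large group and meta to a trifluoromethyl group. Within the data shown here, one measured step bears on it: a 4.7-fold higher number from compound 1 to compound 2 (0.67 log units; beyond the scatter) with piperazin-1-yl in place of 2-methyl-1,3-oxazol-4-yl on an aromatic carbon. The new change also removes piperazin-1-yl, so that step, run backwards, is a rough guide only. Among the measured compounds shown here, no measured step covers 6-fluoropyridin-3-yl itself. A modest fall of similar size is therefore expected, and the expected move is a 5.8-fold lower number from compound 2 to compound 3 (0.76 log units; beyond the scatter) (an estimate). For compound 3 the estimated value is 50000 nM (expected range 15000 nM to 150000 nM).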

Compound 3, solubility: 21000 nM
For compound 3 the middle estimate is 2.4-fold (0.38 log units) above the measured one; measured number inside the range.
By their numbers in this assay, from the lowest: compound 3; then compound 1; then compound 2.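

In this assay this aromatic carbon, ortho to a large group, proves highly sensitive to the group it carries: the change to 6-fluoropyridin-3-yl gives a 14-fold lower number from compound 2 to compound 3 (1.14 log units; beyond the scatter) and is the largest step among the three compounds. Within the data shown here, the two aromatic rings also separate, with a 2.9-fold lower number from compound 1 to compound 3 (0.46 log units; beyond the scatter) as the step between them, so the fall from piperazin-1-yl depends on which aromatic ring enters, and across these compounds the non-aromatic ring of compound 2 gives the highest number, with no compound going against this. No supporting measurement is available to explain these differences.

As far as these compounds go, it remains open whether the high number of compound 2 follows the piperazine ring as a whole or its ring nitrogens, which a morpholine ring or an open-chain amine at this carbon would test. From the compounds shown here alone, the part played by the fluorine of 6-fluoropyridin-3-yl also remains open, and a pyridin-3-yl group without fluorine would address it.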